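The source may hold more compounds than are shown below. What is called first, only, known or untested is meant among the compounds shown, and "the series" means these compounds.

In a functional assay on the whole organism with Mus musculus as the target, in the maximal electroshock model, with a stated time of 0.5 h (a higher number here means that more compound is needed for the effect, a lower number that less compound is needed), compound 1 `COc1ccc2nc(NC(=O)CCC(=O)c3ccccc3)sc2c1` gives 30 mg/kg. Compound 2 `O=C(Nc1nc2ccc(Br)cc2s1)c1ccccc1C(=O)c1ccccc1` gives 300 mg/kg in this assay, the higher of the two numbers, and its distance from compound 1 lies beyond the scatter. Compound 3 `O=C(Nc1nc2ccc([N+](=O)[O-])cc2s1)c1ccccc1C(=O)c1ccccc1` differs from compound 2 by nitro in place of bromo on an aromatic carbon. Among the measured compounds shown here, no measured pair shows what this change does, so compound 3 is expected to stay close to compound 2. The expected step is no change at the digits printed from compound 2 to compound 3 (within the scatter), not beyond the scatter. Compound 3 is therefore estimated at 300 mg/kg, with a range from 100 mg/kg to 1000 mg/kg.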

Compound 3, minimum effective dose: 300 mg/kg
Compound 3: the middle estimate sits on the measured number at the digits printed; the range from low to high includes it.
By their numbers in this assay, from the lowest: compound 1; then compounds 2 and 3 (each within the scatter of the next).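

In this assay, nitro in place of bromo on an aromatic carbon gives no change at the digits printed from compound 2 to compound 3 (within the scatter). The earlier compounds shown here offered no pair that spoke to this position; this pair shows that here a single bromine can give way to nitro, with its three heavy atoms and two hydrogen-bond acceptors, without a step beyond the scatter. No measured property of these compounds bears on this result. The compounds shown leave open whether an amine or a carboxylic acid on this aromatic carbon would also leave the number unchanged. They also leave open whether nitro in place of bromo would behave the same way on the core of compound 1.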